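Aryl substituent on the shared core: a 4-methylphenyl analogue

The source may hold more compounds than are shown below. What is called first, only, known or untested is meant among the compounds shown, and "the series" means these compounds.

Among the measured compounds shown here, compound 3 `COc1cccc(-c2noc(COc3ccc(CCC(=O)O)cc3)n2)c1` gives 2670 nM in a functional assay on CHO cells for agonist activity at Free fatty acid receptor 1 (Homo sapiens), read by FLIPR and calcium flux, in the presence of a further agent that is not named here (a lower number here means that less compound is needed, a higher number that more compound is needed for the effect), the highest of the three numbers measured so far. Compound 1 `O=C(O)CCc1ccc(OCc2nc(-c3ccc(F)cc3)no2)cc1` gives 680 nM, and compound 2 `CCc1ccc(-c2noc(COc3ccc(CCC(=O)O)cc3)n2)cc1` gives 210 nM. Compound 4 `Cc1ccc(-c2noc(COc3ccc(CCC(=O)O)cc3)n2)cc1` carries the change (4-methylphenyl in place of 3-methoxyphenyl on an aromatic carbon). For the measured compounds named here, three measured steps bear on it. Read in reverse, a 3.9-fold higher number from compound 1 to compound 3 (0.59 log units; beyond the scatter) and a 13-fold higher number from compound 2 to compound 3 (1.10 log units; beyond the scatter) show that exchanging 3-methoxyphenyl for either 4-fluorophenyl or 4-ethylphenyl lowers the number, the second of these markedly; a 3.2-fold lower number from compound 1 to compound 2 (0.51 log units; beyond the scatter) separates those two para-substituted rings from each other. A 4-methylphenyl ring is expected to land between compound 1 and compound 2, so for compound 4 a step of a 7.6-fold lower number from compound 3 to compound 4 (0.88 log units; beyond the scatter) is expected in this assay, a clear lowering beyond the scatter. Going by the values given here, the estimate for compound 4 in this assay is 350 nM, with a range from 130 nM to 950 nM; the range is kept wide since no methyl-bearing ring has yet been measured.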

Compound 4, half-maximal effective concentration: 300 nM
Estimate against measurement, compound 4: 1.2-fold (0.07 log units) above; the measured number falls inside the stated range.
By their numbers in this assay, from the lowest: compounds 2 and 4 (each within the scatter of the next); then compound 1; then compound 3.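

In this assay, 4-methylphenyl on the shared core gives an 8.9-fold lower number from compound 3 to compound 4 (0.95 log units; beyond the scatter), and the ring with one carbon fewer in its chain is not separated from 4-ethylphenyl: a 1.4-fold higher number from compound 2 to compound 4 (0.15 log units; within the scatter). Against 4-fluorophenyl, methyl in place of fluoro gives a 2.3-fold lower number from compound 1 to compound 4 (0.36 log units; beyond the scatter), so both alkyl-bearing rings now stand apart from the fluoro ring, and the shorter methyl is enough at this position. Nothing shown here gives a measured reason for these differences.

Compound 3 differs from compound 4 in both the group on the ring and where it sits, so a 4-methoxyphenyl ring would be needed to tell these two changes apart. Also open, on these data alone, is whether a longer chain, as in a 4-propylphenyl ring, keeps the number at this level.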